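This account rests on a few compounds, and the source may have more. Where it says the series, first, only, none or still open, it means among the compounds named here.

Compound 1 `Cc1c(C(=O)Nc2c(F)cc(-c3cccc(F)c3)cc2F)nc2ccc(F)cc2c1O` was tested in a functional assay on A-375 cells (Homo sapiens) for antiproliferative activity, read by MTT assay, with a stated time of 24 h, tested at 33.33 ug/mL (a higher number here means a stronger effect of the compound at the concentration tested, a lower number a weaker effect), where compound 1 gives 28.8%. Compound 3 `Cc1c(C(=O)Nc2c(F)cc(-c3cccc(F)c3)cc2F)nc2ccc(F)cc2c1C(=O)O` carries the change carboxy in place of hydroxy on an aromatic carbon relative to compound 1, and in this assay compound 3 gives 41.3%, so that a number 12.5 percentage points higher from compound 1 to compound 3 (beyond the scatter). Compound 2 `COc1ccc2nc(C(=O)Nc3ccc(-c4ccccc4)cc3)c(C)c(O)c2c1` rests on a different core; how its core differs from that of compound 1 is not broken down here. In this assay compound 2 gives 46.3%, the highest of the three numbers, though its gap to compound 3 lies within the scatter. Compound 4 `COc1ccc2nc(C(=O)Nc3ccc(-c4ccccc4)cc3)c(C)c(C(=O)O)c2c1` differs from compound 2 by carboxy in place of hydroxy on an aromatic carbon, the same change as from compound 1 to compound 3. The step of a number 10.7 percentage points higher from compound 2 to compound 4 (beyond the scatter) is expected for compound 4, resting on the earlier step of a number 12.5 percentage points higher from compound 1 to compound 3 (beyond the scatter). Compound 4 is therefore estimated at 57%, between 42% and 70%.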

Compound 4, a percentage reported as inhibition, at one concentration (the size of the read-out at that concentration, not a potency): 58.3%
Beside the measured number, compound 4's estimate is 1.3 percentage points below it; the measured number falls inside the stated range.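

In this assay, carboxy in place of hydroxy on an aromatic carbon gives a number 12 percentage points higher from compound 2 to compound 4 (beyond the scatter). For the compounds shown here, the change thus carried over from one core to the other at much the same size: the same change on two cores in this assay, a number 12.5 percentage points higher (beyond the scatter) from compound 1 to compound 3 and a number 12 percentage points higher (beyond the scatter) from compound 2 to compound 4, 0.5 percentage points apart, within the scatter of two such steps This rests on only two pairs of compounds, read at a single concentration, so it does not show that the step would hold on any further core, and it gives no potency.

The compounds shown leave open whether another group at this place, such as an amine, a nitrile or a carboxamide, would read like carboxy or like hydroxy. They also leave open how the methyl ester of the carboxy group would read in this assay.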